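The compounds below may be only part of what the source reports. "The series", "measured", "known", "first", "only" and "open" are said of these compounds alone.

Compound 1, `O=C1O[C@H]([C@@H](O)Cn2cc(-c3cccc(O)c3)nn2)C(OCc2ccccc2)=C1OCc1ccccc1`: 59900 nM
Compound 2, `O=C1O/C(=C\Cn2cc(-c3ccc(Br)cc3)nn2)C(OCc2ccccc2)=C1OCc1ccccc1`: > 100000 nM
Compound 3, `O=C1O/C(=C\Cn2cc(-c3cc(C(F)(F)F)cc(C(F)(F)F)c3)nn2)C(OCc2ccccc2)=C1OCc1ccccc1`: > 100000 nM

Of the compounds shown here, three have been tested in a functional assay on A549 cells (Homo sapiens) for antiproliferative activity, read by MTT assay, with a stated time of 72 h; a lower number here means a stronger inhibitor, a higher number a weaker inhibitor. Going by the values given here, compound 1 gives 59900 nM, the only number among the three. For compound 2 the result is a limit of this assay, > 100000 nM. For compound 3 the result is likewise a limit, > 100000 nM. Among the compounds with values here, compound 1 therefore stands alone as the one compound with a value inside the working range of this assay; the rest of the set is described by the limit of > 100000 nM in this assay, at which 2 of the 3 values shown sit. Compound 1 itself is a weak inhibitor.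

Compound 4 `O=C1O[C@H]([C@@H](O)Cn2cc(CCCCl)nn2)C(OCc2ccccc2)=C1OCc1ccccc1` differs from compound 1 in one place: 3-chloropropyl in place of 3-hydroxyphenyl on an aromatic carbon. Within the data shown here, no pair of measured compounds differs by this change alone, so the size of the step cannot be read from the measured values, and the expectation rests on compound 1 alone. Compound 4 is expected to give 80000 nM, with a range from 30000 nM to 200000 nM. That estimate means an expected step of a 1.3-fold higher number from compound 1 to compound 4 (0.13 log units; within the scatter), small and toward weaker inhibition, with a real chance that this assay returns only a limit.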

Compound 4, half-maximal inhibitory concentration: 29000 nM
Compound 4: the middle estimate sits 2.8-fold (0.44 log units) above what was measured; the whole stated range lies above it.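

The step shows that in this assay this place on the five-membered aromatic ring with 3 nitrogen does not depend on an aromatic ring or a hydrogen-bond donor: 3-chloropropyl in place of 3-hydroxyphenyl gives a 2.1-fold lower number from compound 1 to compound 4 (0.32 log units; beyond the scatter). Compound 4 is still a weak inhibitor, but it is a second compound with a value inside the working range, and it carries an open chain with no ring at this place. The remainder of the set stays at a limit of the assay: the limit of > 100000 nM in this assay, at which 2 of the 4 values shown sit.

From the compounds shown here alone, it remains open whether the chlorine or the chain itself accounts for the step, which a plain propyl, a 3-hydroxypropyl or a 3-aminopropyl group could separate. A longer chain, or an unsubstituted phenyl in place of 3-hydroxyphenyl, would also test how much this place can change.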